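A third hydroxy on the benzylidene ring

The compounds below may be only part of what the source reports. "The series", "measured", "known", "first", "only" and "open" are said of these compounds alone.

This series shares one core with a hydrazone arm. Compound 1 `Cc1c(C(=O)N/N=C\c2c(O)cccc2F)oc2cccc(O)c12` carries a 2-fluoro-6-hydroxyphenyl on the carbon with a double bond to nitrogen; in a functional assay on U-87MG ATCC cells for inhibition, with U-87 MG (Homo sapiens) as the target (on this read-out higher numbers stand for weaker inhibition and lower numbers for stronger inhibition), compound 1 gives 9270 nM. Compound 2 `Cc1c(C(=O)N/N=C\c2ccc(O)cc2O)oc2cccc(O)c12` carries a 2,4-dihydroxyphenyl there instead, and in this assay compound 2 gives 4390 nM. That change gave a 2.1-fold lower number from compound 1 to compound 2 (0.32 log units; beyond the scatter). Among the two measured compounds, compound 2 therefore stands with the lowest number, which on this read-out means the stronger inhibition.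

Compound 3 `Cc1c(C(=O)N/N=C\c2ccc(O)c(O)c2O)oc2cccc(O)c12` is the next step: it differs from compound 2 by hydroxy in place of hydrogen on an aromatic carbon. Among the measured compounds shown here, no measured step in this set exchanges hydrogen for hydroxy directly; the only step available, from compound 1 to compound 2, was modest and already involved hydroxy groups. On that thin basis the step from compound 2 to compound 3 is expected to be small, a 1.3-fold lower number from compound 2 to compound 3 (0.10 log units; within the scatter), in the direction of stronger inhibition or not beyond the scatter. Compound 3 is thus expected to give about 3500 nM in this assay, within a range from 1400 nM to 9000 nM.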

Compound 3, half-maximal inhibitory concentration: 5960 nM
Compound 3: middle estimate off by 1.7-fold (0.23 log units), on the low side; low and high end bracket the measured number.
By their numbers in this assay, from the lowest: compounds 2, 3 and 1 (each within the scatter of the next, the first and the last beyond it).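

Among the compounds shown here, this is the first direct exchange of hydrogen for hydroxy, and it gives a 1.4-fold higher number from compound 2 to compound 3 (0.13 log units; within the scatter). With a hydroxy on an aromatic carbon ortho to two hydroxy groups, compound 3 therefore cannot be told apart from compound 2 in this assay, so this carbon accepts one more hydroxy without a change that can be read beyond the usual scatter of repeated measurements. For the compounds shown here, the step also shows that a third hydroxy on the ring brings no clear gain over two, at least at this carbon, and nothing measured so far explains this result.

On these data alone, what remains open is whether a different group on this same carbon, such as a methoxy, an amine or a carboxylic acid, would move the number beyond the scatter in either direction. It is also unknown whether the exchange of hydrogen for hydroxy would read the same on a ring without the two hydroxy groups that compound 2 and compound 3 both carry, since only this one exchange is shown here.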